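A Second Methyl on the Central Ring of a Receptor Agonist

The source may report more compounds than this note shows. Statements on the series, on what has been measured and on what is new or still open speak of the compounds shown alone.

Compound 1 `Cc1ccc(Oc2ccc(CC3SC(=O)NC3=O)cc2)cc1` is the simplest member of this small set. In a functional assay for agonist activity at Free fatty acid receptor 1 (Homo sapiens), read by FLIPR, in the presence of a further agent that is not named here (on this read-out higher numbers stand for an effect only at larger amounts of compound and lower numbers for an effect already at smaller amounts), compound 1 gives 547 nM. Compound 3 `Cc1ccc(Oc2ccc(CC3SC(=O)NC3=O)cc2)c(C)c1` carries one extra group; the change is methyl in place of hydrogen on an aromatic carbon. In this assay compound 3 gives 121 nM, so the step is a 4.5-fold lower number from compound 1 to compound 3 (0.66 log units; beyond the scatter).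

Compound 2 `Cc1cc(Oc2ncc(C(F)(F)F)cc2Cl)ccc1CC1SC(=O)NC1=O` is built on a different core, and the difference between the two cores is not broken down here. In this assay compound 2 gives 10 nM, the lowest of the three measured numbers, with compound 3 and then compound 1 standing well above it.

Compound 4 `Cc1cc(Oc2ncc(C(F)(F)F)cc2Cl)cc(C)c1CC1SC(=O)NC1=O` has not yet been measured. It differs from compound 2 by methyl in place of hydrogen on an aromatic carbon. Going by the values given here, this is the same kind of change as the one from compound 1 to compound 3, but not the same: in compound 3 the new methyl sits ortho to a large group and meta to a methyl group, whereas in compound 4 it sits ortho to a (2,4-dioxo-1,3-thiazolidin-5-yl)methyl group, meta to a large group and meta to a methyl group.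

Because the step from compound 1 to compound 3 was a 4.5-fold lower number from compound 1 to compound 3 (0.66 log units; beyond the scatter), a further methyl is expected to help somewhat, but the different surroundings make a smaller step from compound 2 to compound 4 the more cautious expectation, estimated as a 1.4-fold lower number from compound 2 to compound 4 (0.15 log units; within the scatter). Compound 4 is therefore expected to give about 7 nM in this assay, likely between 2 nM and 25 nM.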

Compound 4, half-maximal effective concentration: 5450 nM
For compound 4 the middle estimate is 780-fold (2.89 log units) below the measured one; the measured number lies above the stated range.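

In this assay, a methyl in place of hydrogen on an aromatic carbon, ortho to a (2,4-dioxo-1,3-thiazolidin-5-yl)methyl group, meta to a large group and meta to a methyl group, gives a 550-fold higher number from compound 2 to compound 4 (2.74 log units; beyond the scatter). In this series, the same kind of change therefore does not carry over from one core to the other, either in direction or in size: the same change on two cores in this assay, a 4.5-fold lower number (0.66 log units; beyond the scatter) from compound 1 to compound 3 and a 550-fold higher number (2.74 log units; beyond the scatter) from compound 2 to compound 4, 2500-fold (3.39 log units) apart, beyond the scatter of two such steps What this does not show is the reason: the two new methyl groups differ in their surroundings as well as in their cores, so these two steps cannot separate the effect of the methyl's place from that of the rest of the molecule, and they give no rule for any other core.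

The compounds shown leave open whether a methyl on the core of compound 2, set in the place it holds in compound 3, would lower the number, and how the core of compound 1 would respond to a methyl placed as in compound 4. They also leave open how a methoxy group or an ethyl group would fare on the carbon that carries the new methyl in compound 4.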